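Phenyl in place of tert-butyl on a plasma-assay scaffold

A few compounds are considered here, and "the series" means these few. Any claim that something is new, unique, unknown or untested is made for them only; others in the source may bear on it.

Of the compounds shown here, two have been measured so far. Compound 1 `O=C(NCc1cc(Cl)ccc1-n1cnnn1)[C@@H]1[C@H]2C[C@H]2CN1C(=O)[C@H](O)CC1CC1` was tested in a functional assay on a cell-free system (plasma, Homo sapiens), with a stated time of 3 min (a lower number here means a stronger inhibitor, a higher number a weaker inhibitor), where compound 1 gives 1400 nM. Compound 2 `CC(C)(C)[C@@H](O)C(=O)N1OCC[C@H]1C(=O)NCc1cc(Cl)ccc1-n1cnnn1` is the other; in this assay compound 2 gives 1600 nM. Compound 2 holds the higher of the two numbers, but its nearest neighbour is compound 1 and the gap between them lies within the usual scatter, so the two cannot be told apart on these data. Compound 3 `O=C(NCc1cc(Cl)ccc1-n1cnnn1)[C@@H]1CCON1C(=O)[C@H](O)c1ccccc1` has not yet been measured. It differs from compound 2 in one place: phenyl in place of tert-butyl on a saturated chain carbon bound to a carbonyl carbon and an oxygen on a saturated carbon. Among the measured compounds shown here, no measured pair tracks this change, so its effect cannot be read from what is known. The step of no change at the digits printed from compound 2 to compound 3 (within the scatter) is expected to be small, in either direction, and not clearly beyond the scatter. Compound 3 is therefore estimated at 1600 nM, with a range from 500 nM to 5000 nM.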

Compound 3, half-maximal inhibitory concentration: 1500 nM
Beside the measured number, compound 3's estimate is 1.1-fold (0.03 log units) above it; the measured number falls inside the stated range.
By their numbers in this assay, from the lowest: compounds 1, 3 and 2 (each within the scatter of the next).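

In this assay, the change of tert-butyl to phenyl gives a 1.1-fold lower number from compound 2 to compound 3 (0.03 log units; within the scatter), so the two groups cannot be told apart at this position. Among the compounds shown here, this is the first pair that differs in one place, and it shows that a saturated branched group of 4 carbons and a six-membered aromatic ring of 6 carbons can occupy this saturated chain carbon with no readable shift in the number. No measurement is at hand that could explain this likeness.

This one pair does not show whether the position accepts anything at all or only these two carbon-only groups. An amine, a carboxylic acid or a longer chain in the same place, or a phenyl carrying a chlorine, could still move the number beyond the scatter.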